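Changing the acyl group on a sulfonate amide

The source may report more compounds than this note shows. Statements on the series, on what has been measured and on what is new or still open speak of the compounds shown alone.

Compound 1 `COc1ccc(S(=O)(=O)Oc2ccccc2NC(=O)c2ccc3ncccc3c2)cc1`: > 10000 nM (a limit)
Compound 2 `COc1ccc(S(=O)(=O)Oc2ccccc2NC(=O)c2ccc(F)cc2)cc1`: 89 nM
Compound 3 `COc1ccc(S(=O)(=O)Oc2ccccc2NC(=O)c2ccc(N(C)C)cc2)cc1`: > 10000 nM (a limit)

In a functional assay on HCT-15 cells (Homo sapiens) for antiproliferative activity (a higher number here means a weaker inhibitor, a lower number a stronger inhibitor), compound 3 gives only a limit, > 10000 nM, and not an exact number. It shares that position with one other compound: the limit of > 10000 nM in this assay, at which 2 of the 3 values shown sit.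

Compound 4 `COc1ccc(S(=O)(=O)Oc2ccccc2NC(=O)c2ccco2)cc1` differs from compound 3 in one place: furan-2-yl in place of 4-(dimethylamino)phenyl on a carbonyl carbon. Furan-2-yl takes the place of 4-(dimethylamino)phenyl on a carbonyl carbon.

Among the compounds with values here, two measured steps bear on this change: an at least 110-fold lower number from compound 1 to compound 2 (2.05 log units; beyond the scatter) and an at least 110-fold higher number from compound 2 to compound 3 (2.05 log units; beyond the scatter). Both are large, so a change of this kind can move the number a long way. Within the data shown here, no measured compound carries furan-2-yl, so the direction is uncertain, and compound 4 could stay at the limit. A sizeable drop in the number remains the more likely outcome in this assay.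

The expected change is an at least 6.6-fold lower number from compound 3 to compound 4 (0.82 log units; beyond the scatter).

For compound 4 the estimated value is 1500 nM, with an expected range from 100 nM to 10000 nM.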

Compound 4, half-maximal inhibitory concentration: 19 nM
The estimate for compound 4 lay 79-fold (1.90 log units) above the measured number, outside the stated range (below it).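

With furan-2-yl on the carbonyl carbon, a second group at this position gives a measured number in this assay, and it goes beyond 4-fluorophenyl: a 4.7-fold lower number from compound 2 to compound 4 (0.67 log units; beyond the scatter), a modest step. The other two steps start from limits, so each gives only a minimum size, and both are large: an at least 520-fold lower number from compound 3 to compound 4 (2.72 log units; beyond the scatter), and an at least 520-fold lower number from compound 1 to compound 4 (2.72 log units; beyond the scatter). A five-membered ring with one oxygen therefore works at this position, while the swap of fluoro for dimethylamino shows that a phenyl ring alone does not settle the outcome, and two compounds remain limits rather than numbers: the limit of > 10000 nM in this assay, at which 2 of the 4 values shown sit.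

Going by these compounds, what a thiophen-2-yl or an unsubstituted phenyl group would give at this carbonyl carbon stays open. So does whether the ring oxygen of furan-2-yl matters at all.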